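Swapping a hydroxycyclohexylmethyl arm for a carbamoyl cyclobutyl ring

The compounds below may be only part of what the source reports. "The series", "measured", "known", "first", "only" and "open" are said of these compounds alone.

Of the compounds shown here, three from one series have been tested in an assay on isolated protein for inhibition of protein kinase C delta type (Homo sapiens), read by TR-FRET, with a stated time of 2 h; on this read-out lower numbers stand for stronger inhibition and higher numbers for weaker inhibition. Compound 1, with the structure `N#Cc1cnc(NCc2cnccc2C(F)(F)F)cc1NC[C@H]1CC[C@@H](O)CC1`, gives 500 nM in this assay. Compound 3, with the structure `N#Cc1cnc(NCc2cnccc2C(F)(F)F)cc1N[C@H]1CC[C@@H](c2nc[nH]n2)CC1`, gives 1200 nM, and compound 2, with the structure `N#Cc1cnc(NCc2ccccc2C(F)(F)F)cc1N[C@H]1C[C@@H](C(N)=O)C1`, gives 4200 nM. Compound 1 thus has the lowest number of the three, and its separation from each of the other two lies beyond the usual scatter of repeated measurements, so it is the strongest inhibitor among them.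

Compound 4, with the structure `CC1(C)[C@@H](C(N)=O)C[C@H]1Nc1cc(NCc2cnccc2C(F)(F)F)ncc1C#N`, has not yet been measured. It differs from compound 1 in one place: 3-carbamoyl-2,2-dimethylcyclobutyl in place of (4-hydroxycyclohexyl)methyl on a nitrogen on an aromatic ring. Going by the values given here, no pair of measured compounds differs by exactly this change, so nothing in the data fixes the size of its step. Compound 2, which also carries a carbamoyl-bearing cyclobutyl ring on the same nitrogen, gives 4200 nM, the weakest number of the three, though it also differs elsewhere. On that basis a moderate step toward weaker inhibition is expected, a 3.0-fold higher number from compound 1 to compound 4 (0.48 log units; beyond the scatter), with compound 4 estimated at 1500 nM and a range of 400 nM to 6000 nM.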

Compound 4, half-maximal inhibitory concentration: 160 nM
Compound 4: the middle estimate sits 9.4-fold (0.97 log units) above what was measured, outside the stated range (below it).
By their numbers in this assay, from the lowest: compound 4; then compound 1; then compound 3; then compound 2.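

In this assay the nitrogen on an aromatic ring of the shared core tolerates a large change of arm: 3-carbamoyl-2,2-dimethylcyclobutyl in place of (4-hydroxycyclohexyl)methyl gives a 3.1-fold lower number from compound 1 to compound 4 (0.49 log units; beyond the scatter) and this modest step lies beyond the usual scatter. Going by these compounds alone, this is the first direct reading at this position, as the earlier compounds each differ from one another in more than one place. Nothing shown bears on why the number fell.

As far as these compounds go, the step changes the ring, the two methyl groups and the carbamoyl group all at once, so the share of each remains open. A carboxylic acid in place of the carbamoyl group, or the same cyclobutyl arm without its two methyl groups on the core of compound 4, would begin to separate them.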